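Chain Length and Demethylase Inhibition: From Compound 3 to Compound 4

The source may hold more compounds than are shown below. What is called first, only, known or untested is meant among the compounds shown, and "the series" means these compounds.

Measured so far in an assay on isolated protein for inhibition of lysine-specific demethylase 5A (Homo sapiens), with a stated time of 60 min; on this read-out lower numbers stand for stronger inhibition and higher numbers for weaker inhibition:
Compound 1, `CCCCN(C)CCCCC(=O)N(O)CCC(=O)O`, gives 4300 nM.
Compound 2, `CCCCN(C)CCC(=O)N(O)CCC(=O)O`, gives 53000 nM.
Compound 3, `CCCCN(C)CCCCCC(=O)N(O)CCC(=O)O`, gives 4000 nM.

Compound 3 carries the lowest number of the three. Its nearest neighbour is compound 1, whose number is only a little higher, a gap that lies within the usual scatter of this assay, so the two cannot be ranked against each other. Compound 2, the shortest chain of the set, gives a number far higher than compound 3, a gap well beyond the scatter, and is therefore the clearly weaker of the pair.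

Compound 4, `CCCCN(C)CCCCCCC(=O)N(O)CCC(=O)O`, has not yet been measured in this assay. It differs from compound 3 in one place: (butyl(methyl)amino)methyl in place of butyl(methyl)amino on a saturated chain carbon, five bonds along the chain from a carbonyl carbon. In plain terms, the chain between the amine and the carbonyl grows by one more link.

Within the data shown here, no step between measured compounds isolates this exact change. What the numbers show is that the two longer chains, compound 1 and compound 3, sit within the scatter of one another, while only the much shorter chain of compound 2 falls away. On that basis the step from compound 3 to compound 4 in this assay is expected to be small, with no clear direction beyond the scatter, no change at the digits printed from compound 3 to compound 4 (within the scatter). Compound 4 is therefore estimated to give 4000 nM, within a range from 1500 nM to 11000 nM.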

Compound 4, half-maximal inhibitory concentration: 1800 nM
Beside the measured number, compound 4's estimate is 2.2-fold (0.35 log units) above it; measured number inside the range.
By their numbers in this assay, from the lowest: compound 4; then compounds 3 and 1 (each within the scatter of the next); then compound 2.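

In this assay, among these compounds, the one added link gives a 2.2-fold lower number from compound 3 to compound 4 (0.35 log units; beyond the scatter) and so provides the first single change in this set whose effect can be read directly. At this position, on a saturated chain carbon, five bonds along the chain from a carbonyl carbon, the longer chain lowers the number by a modest but real amount. The earlier values could not show this: compound 1 and compound 3 stand within the scatter of each other, which made it look as if chain length had stopped mattering, whereas compound 4 now carries the lowest number of the four.

On these data alone, whether a still longer chain would lower the number further or raise it again remains open, as does the effect of a phenyl ring or an ether oxygen within the chain, or of a benzyl group in place of butyl on the amine. The data shown offer no measurement that accounts for this step, so the reason for the lower number remains unknown.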